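Defluorination of compound 1: expected effect on enzyme inhibition

The source may hold more compounds than are shown below. What is called first, only, known or untested is meant among the compounds shown, and "the series" means these compounds.

Series notes. In an assay on isolated protein for inhibition of 3-oxo-5-alpha-steroid 4-dehydrogenase 2 (Homo sapiens) (a lower number here means a stronger inhibitor, a higher number a weaker inhibitor), compound 1, `O=C(O)c1ccc(C=C2CCN(C(=O)C(c3ccccc3)c3ccccc3)CC2)c(F)c1`, gives 410 nM. Among the three measured compounds this places compound 1 second highest. Its nearest neighbour is compound 3, `O=C(O)c1ccc(C=C2CCN(C(=O)CC(c3ccccc3)c3ccccc3)CC2)cc1`, which in this assay gives 1100 nM, a gap beyond the scatter. The furthest is compound 2, `O=C(O)Cc1ccc(C=C2CCN(C(=O)C(C3CCCCC3)C3CCCCC3)CC2)cc1`, which in this assay gives 6 nM, far below compound 1 and well beyond the scatter. Compound 2 differs from compound 1 in more than one place, so nothing in these three numbers isolates any single change.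

Compound 4, `O=C(O)c1ccc(C=C2CCN(C(=O)C(c3ccccc3)c3ccccc3)CC2)cc1`, is not yet measured. It differs from compound 1 by hydrogen in place of fluoro on an aromatic carbon, ortho to a large group and meta to the carboxy group. For the measured compounds named here, no measured pair shows this change on its own. The expectation is a step of modest size, if any, with a slight lean toward a higher number, and it may well fall within the scatter. The step from compound 1 to compound 4 is estimated at a 1.3-fold higher number from compound 1 to compound 4 (0.13 log units; within the scatter). Compound 4 is expected to give 550 nM in this assay, within a range from 180 nM to 1700 nM.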

Compound 4, half-maximal inhibitory concentration: 530 nM
The estimate for compound 4 lay 1.0-fold (0.02 log units) above the measured number; measured number inside the range.
By their numbers in this assay, from the lowest: compound 2; then compounds 1 and 4 (each within the scatter of the next); then compound 3.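

In this assay, for the compounds shown here, replacing 4-carboxy-2-fluorophenyl with 4-carboxyphenyl gives the first reading of a single change: a 1.3-fold higher number from compound 1 to compound 4 (0.11 log units; within the scatter). Going by these compounds alone, at this aromatic carbon, ortho to a large group and meta to a carboxy group, the fluoro group can therefore be replaced by hydrogen with no change in inhibition that can be told from the scatter, something the earlier compounds could not show, as no pair among them differed in one place. No measurement at hand bears on the reason for this result.

Going by these compounds, whether other groups on this same carbon, such as a chlorine atom, a methoxy group or an amine, would also leave the number within the scatter remains open. Also open, on these data alone, is whether a fluoro group on the aromatic ring of compound 2, which gives 6 nM, would produce a similarly small step on that different structure.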